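The source may hold more compounds than are shown below. What is called first, only, known or untested is meant among the compounds shown, and "the series" means these compounds.

Measured values in an assay on isolated protein for agonist activity at Bile acid receptor (Homo sapiens), read by AlphaScreen, with a stated time of 30 min; on this read-out higher numbers stand for an effect only at larger amounts of compound and lower numbers for an effect already at smaller amounts:

compound 1, `Cc1nn(-c2ccccc2I)c2c1C(c1ccc(Oc3ccccc3)cc1)SC(C)C(=O)N2`: 1300 nM
compound 2, `Cc1nn(-c2ccccc2Cl)c2c1C(c1ccc(Oc3ccccc3)cc1)SC(C)C(=O)N2`: 2700 nM
compound 3, `Cc1ccccc1-n1nc(C)c2c1NC(=O)[C@H](C)S[C@@H]2c1ccc(-c2ccsc2)cc1`: 1400 nM

Compound 3 stands second highest of the three numbers in this assay; its value lies within the scatter of both compound 1 and compound 2, so no order among them can be claimed. Among the compounds with values here, the only step within the measured set, chloro in place of iodo on an aromatic carbon, gives a 2.1-fold higher number from compound 1 to compound 2 (0.32 log units; beyond the scatter).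

Compound 4, `Cc1ccccc1-n1nc(C)c2c1NC(=O)[C@H](C)S[C@@H]2c1ccc(Oc2ccccc2)cc1`, differs from compound 3 by phenoxy in place of thiophen-3-yl on an aromatic carbon. Within the data shown here, no measured step covers this exchange, so the halogen step does not bear on it directly. Compound 1 carries the phenoxy group at the same place as compound 4, on an otherwise differently substituted core. What the data do show is that compound 1 gives 1300 nM, within the scatter of compound 3. The expectation for compound 4 is therefore a step of no change at the digits printed from compound 3 to compound 4 (within the scatter), that is none beyond the scatter. Compound 4 is estimated at 1400 nM in this assay, with a range from 500 nM to 4000 nM.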

Compound 4, half-maximal effective concentration: 1300 nM
The estimate for compound 4 lay 1.1-fold (0.03 log units) above the measured number; low and high end bracket the measured number.
By their numbers in this assay, from the lowest: compounds 1, 4, 3 and 2 (each within the scatter of the next, the first and the last beyond it).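

In this assay, phenoxy in place of thiophen-3-yl on this aromatic carbon gives a 1.1-fold lower number from compound 3 to compound 4 (0.03 log units; within the scatter) and so separates the two groups by no more than the usual scatter. The place, para to a large group, therefore accepts either a five-membered aromatic ring with one hetero atom or a phenoxy group carrying a six-membered aromatic ring of carbon only, with no readable difference on this read-out. Nothing measured here accounts for this result.

From the compounds shown here alone, whether this place stays as undemanding for a carboxylic acid, an amine or a longer chain such as benzyloxy remains open. Within the data shown here, the single exchange also leaves open whether the same two groups would again fall within the scatter on a core carrying different substituents elsewhere.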